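The source may hold more compounds than are shown below. What is called first, only, known or untested is meant among the compounds shown, and "the series" means these compounds.

In a functional assay on T98G cells (Homo sapiens) for inhibition, read by MTT assay, with a stated time of 72 h (a lower number here means a stronger inhibitor, a higher number a weaker inhibitor), compound 1 (`CC1(C)CC(NC(=S)NCc2ccccc2)c2cc(F)ccc2O1`) reads 40000 nM and compound 2 (`CC1(C)CC(NC(=O)Nc2cccc(Cl)c2)c2cc(Br)ccc2O1`) reads 67000 nM while compound 3 (`COc1ccc(NC(=S)NC2CC(C)(C)Oc3ccc(Br)cc32)cc1`) reads 33000 nM on the same scale. Compound 3 stands level with compound 1, since their two values lie within the scatter of each other. Only against compound 2 does compound 3 show a lower number beyond the scatter, so it cannot be called the strongest of the three.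

Compound 4 (`CC1(C)CC(NC(=S)Nc2cccc(C#N)c2)c2cc(Br)ccc2O1`) has not yet been measured. It keeps the rest of compound 3 and exchanges one group, with 3-cyanophenyl in place of 4-methoxyphenyl on an amide-type nitrogen. The entering group brings a triple bond outside aromatic rings. Within the data shown here, no measured pair differs in one place only, so the data offer no direct precedent for this exchange. Among the measured compounds shown here, the only guide is the narrow spread of the measured values, which run from compound 3 at 33000 nM to compound 2 at 67000 nM even though these structures differ in more than one place. The expectation is therefore of no change beyond the scatter, with an estimated step of a 1.1-fold higher number from compound 3 to compound 4 (0.04 log units; within the scatter) that stays small. For compound 4 the estimate is 36000 nM with an expected range from 16000 nM to 80000 nM as its span.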

Compound 4, half-maximal inhibitory concentration: 9000 nM
For compound 4 the middle estimate is 4.0-fold (0.60 log units) above the measured one; measured number below the stated range.
By their numbers in this assay, from the lowest: compound 4; then compounds 3, 1 and 2 (each within the scatter of the next, the first and the last beyond it).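

In this assay, putting 3-cyanophenyl in place of 4-methoxyphenyl on an amide-type nitrogen whose other neighbour is the thiocarbonyl carbon gives a 3.7-fold lower number from compound 3 to compound 4 (0.56 log units; beyond the scatter). Among these compounds, this is the first reading in which a single place changes, and it shows that the read-out responds to the group on this nitrogen, something compounds 1, 2 and 3 could not show, since they differ from one another in more than one place. The two groups match in heavy-atom count and in their counts of hydrogen-bond donors and acceptors, so those counts do not separate them, while the entering group brings a triple bond and a nitrogen where the leaving group has an oxygen; no measurement on hand explains the step.

The exchange removes the methoxy group and brings in the nitrile at once, so the compounds shown cannot say whether the lower number follows the arrival of the nitrile, the loss of the methoxy group or the change in where the substituent sits. They also leave open whether other groups in the nitrile's stead, such as a trifluoromethyl group, a carboxylic acid or an amine, would move the number in the same direction, and whether the step would hold with a carbonyl in place of the thiocarbonyl.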